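Methoxy in Place of Ethylsulfanyl on a Monophosphate Core

The source may hold more compounds than are shown below. What is called first, only, known or untested is meant among the compounds shown, and "the series" means these compounds.

Compound 1 `Nc1nc(=O)ccn1[C@@H]1O[C@H](COP(=O)(O)O)[C@@H](O)[C@H]1O` carries an amino group on the shared core. In an in vitro functional assay on 1321-N1 cells for agonist activity at P2Y purinoceptor 6 (Homo sapiens), read by scintillation proximity assay and inositol phosphate accumulation (on this read-out lower numbers stand for an effect already at smaller amounts and higher numbers for an effect only at larger amounts of compound), compound 1 gives only the limit > 100000 nM, not a number. Compound 2 `CCSc1nc(=O)ccn1[C@@H]1O[C@H](COP(=O)(O)O)[C@@H](O)[C@H]1O` bears ethylsulfanyl at that position, and in this assay compound 2 likewise reports only the limit > 100000 nM. The step that the two limits leave unreadable from compound 1 to compound 2 is therefore unreadable, since both compounds sit at the limit of > 100000 nM in this assay, at which 2 of the 3 values shown sit. Compound 3 `O=c1ccn([C@@H]2O[C@H](COP(=O)(O)OP(=O)(O)O)[C@@H](O)[C@H]2O)c(SCCc2ccccc2)n1` differs from compound 2 in more than one place. In this assay compound 3 gives a number, namely 2500 nM.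

Compound 4 `COc1nc(=O)ccn1[C@@H]1O[C@H](COP(=O)(O)O)[C@@H](O)[C@H]1O` differs from compound 2 as follows: methoxy in place of ethylsulfanyl on an aromatic carbon. Among the compounds with values here, no measured step bears on this exchange, the only one available being unreadable. Compound 2 stands at the limit of this assay, and the replacement of one small uncharged group by another offers no reason to expect movement beyond the scatter. The expected step is a step that the limit leaves unreadable from compound 2 to compound 4. Compound 4 is therefore estimated at 150000 nM, within 50000 nM to 500000 nM, most likely again reported only as a limit.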

Compound 4, half-maximal effective concentration: 9800 nM
Compound 4: middle estimate off by 15-fold (1.18 log units), on the high side; measured number below the stated range.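

On the shared monophosphate core, the group on the aromatic carbon between two ring nitrogen atoms turns out to decide whether a number appears at all in this assay, which neither amino nor ethylsulfanyl had shown. Methoxy in place of ethylsulfanyl gives an at least 10-fold lower number from compound 2 to compound 4 (1.00 log units; beyond the scatter), and methoxy in place of amino gives an at least 10-fold lower number from compound 1 to compound 4 (1.00 log units; beyond the scatter). Both steps are minimum sizes only, and the step between the amino and ethylsulfanyl compounds remains unreadable, since those two compounds rest on a limit: the limit of > 100000 nM in this assay, at which 2 of the 4 values shown sit.

The compounds shown leave open whether the gain is particular to methoxy or would extend to ethoxy, a hydroxyl or a longer chain joined through oxygen. They also leave open how methoxy would behave on a diphosphate, as compound 3 differs from the monophosphates in more than one place.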